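This account rests on a few compounds, and the source may have more. Where it says the series, first, only, none or still open, it means among the compounds named here.

Measured so far in a functional assay on MCF7 cells (Homo sapiens) for cytotoxicity, read by MTT assay; on this read-out lower numbers stand for stronger inhibition and higher numbers for weaker inhibition:
compound 1 `CC(=O)O[C@@H]1OC(=O)[C@](C)(C(C)=O)[C@@H]1C` gives 6000 nM
compound 2 `CC(=O)O[C@@H]1OC(=O)[C@](C)(C(=O)CBr)[C@@H]1C` gives 4000 nM

In this assay, among the compounds with values here, compound 1 stands at 6000 nM as one of only two numbers, and the other lies within the scatter of it, with a 1.5-fold lower number from compound 1 to compound 2 (0.18 log units; within the scatter) as the single measured step. That step is bromo in place of hydrogen on a saturated chain carbon bound to a carbonyl carbon, so it lies at another place than the change considered here. Compound 3 `CCO[C@@H]1OC(=O)[C@](C)(C(C)=O)[C@@H]1C` differs from compound 1 by ethyl in place of acetyl on an oxygen on a saturated carbon and the same difference reads acetoxy to ethoxy. Within the data shown here, no measured step touches this oxygen, and no measured pair shows what this exchange does. Among the measured compounds shown here, the one measured step therefore gives only weak guidance on size. The estimated step is a 1.5-fold higher number from compound 1 to compound 3 (0.18 log units; within the scatter) in this assay and no change beyond the scatter is expected, though the range stays wide for lack of direct evidence. For compound 3 the expected value is 9000 nM with an estimated range from 3000 nM to 30000 nM in this series.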

Compound 3, half-maximal inhibitory concentration: > 50000 nM
Compound 3 ended at the assay's limit (the forecaster's own chance of this, stated with the estimate: 20%); at least 5.5-fold (0.74 log units) between middle value and limit.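

In this assay, within the data shown here, the oxygen on a saturated carbon proves to be a place where the series responds: ethyl in place of acetyl gives an at least 8.3-fold higher number from compound 1 to compound 3 (0.92 log units; beyond the scatter), whereas the only earlier step, a 1.5-fold lower number from compound 1 to compound 2 (0.18 log units; within the scatter), stayed within the scatter and lay at another place. Compound 3 gives > 50000 nM, which is a limit of the assay and not a number: the limit of > 50000 nM in this assay, at which 1 of the 3 values shown sits. The step to ethoxy therefore has only a lower bound on its size, and the two compounds with a numeric value in this series, compound 1 and compound 2, both carry acetoxy.

The compounds shown leave open whether the acetyl group itself is needed here or whether another acyl group, such as propionyl or benzoyl, would serve equally, and a free hydroxyl or an amine at this place would help to separate these readings. They also leave open whether the bromo exchange on the chain carbon bound to a carbonyl carbon reads the same once ethoxy replaces acetoxy on the shared core.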